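The compounds below may be only part of what the source reports. "The series", "measured", "known", "first", "only" and "open" are said of these compounds alone.

Compound 1 `COc1ccc(F)cc1-c1cccc(-c2nn(CCOC3CCCCO3)c(=O)o2)c1` gives 16%
Compound 2 `COc1ccc(F)cc1-c1cccc(-c2nn(CCCN)c(=O)o2)c1` gives 29%

In a functional assay on the whole organism (strain Wistar albino) for inhibition, with Rattus norvegicus as the target, read by paw edema, with stated times of 30 min and 0.5 h, at a dose of 10 mg/kg by the oral route (a lower number here means less inhibition, a higher number more inhibition at the dose given (going by the name of the read-out)), compound 2 stands highest of the two numbers, the other being compound 1. Going by the values given here, the single measured step, a number 13 percentage points higher from compound 1 to compound 2 (beyond the scatter), was modest and changed the group at the end of the chain. Compound 3 `COC(=O)CCCn1nc(-c2cccc(-c3cc(F)ccc3OC)c2)oc1=O` differs from compound 2 by methoxycarbonyl in place of amino on a saturated chain carbon, three bonds along the chain from an aromatic nitrogen. Among the compounds with values here, that earlier step bears on this one only loosely, since no measured pair shows an ester at the chain end, so the direction is uncertain; the expected step is a number 8 percentage points lower from compound 2 to compound 3 (within the scatter), a small fall within the scatter. Compound 3 is estimated at 21%, with a range from 8% to 34%.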

Compound 3, a percentage reported as inhibition, in the whole organism at one dose (the size of the read-out at that dose, not a potency): 31%
The estimate for compound 3 lay 10 percentage points below the measured number; the range from low to high includes it.
By their numbers in this assay, from the lowest: compound 1; then compounds 2 and 3 (each within the scatter of the next).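

In this assay, methoxycarbonyl in place of amino at the chain end gives a number 2 percentage points higher from compound 2 to compound 3 (within the scatter) and so leaves the reading unchanged: the chain end accepts either group here. Compound 3 also holds the advantage over the chain of compound 1, with a number 15 percentage points higher from compound 1 to compound 3 (beyond the scatter) for this change at the chain. Nothing measured here explains these numbers.

Still open, on these data alone, is whether a carboxylic acid at the chain end, or a longer chain, would move the number beyond the scatter.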